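Swapping the Amine on the Thiocarbonyl Carbon: Compound 4 Estimated

The source may report more compounds than this note shows. Statements on the series, on what has been measured and on what is new or still open speak of the compounds shown alone.

Compound 1, `COc1ccc2occ(CSC(=S)N(C(C)C)C(C)C)c(=O)c2c1`: in a functional assay on MCF7 cells (Homo sapiens) for antiproliferative activity, read by MTT assay, with a stated time of 72 h (on this read-out higher numbers stand for weaker inhibition and lower numbers for stronger inhibition), compound 1 gives > 40000 nM, which is a limit of the assay and not a number.
Compound 2, `COc1ccc2occ(CSC(=S)N3CCOCC3)c(=O)c2c1`: compound 2 gives 11800 nM.
Compound 3, `CC(C)N(C(=S)SCc1cc(=O)c2ccccc2o1)C(C)C`: compound 3 gives 31700 nM.

Between compound 1 and compound 2 the change is morpholin-4-yl in place of diisopropylamino on a thiocarbonyl carbon, and it made the step of an at least 3.3-fold lower number from compound 1 to compound 2 (0.53 log units; beyond the scatter). Because compound 1 sits at the limit of > 40000 nM in this assay, at which 1 of the 3 values shown sits, this step is only a lower bound on the true size. The difference between the two cores of compound 1 and compound 3 is not broken down here. Compound 4, `O=c1cc(CSC(=S)N2CCOCC2)oc2ccccc12`, is not yet measured; it differs from compound 3 by morpholin-4-yl in place of diisopropylamino on a thiocarbonyl carbon, the same change at the same kind of place. The step for compound 4 is expected to be a 3.2-fold lower number from compound 3 to compound 4 (0.50 log units; beyond the scatter), resting on the measured step of an at least 3.3-fold lower number from compound 1 to compound 2 (0.53 log units; beyond the scatter). Compound 4 is therefore estimated at 10000 nM, with a likely range from 4000 nM to 25000 nM.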

Compound 4, half-maximal inhibitory concentration: 21000 nM
Compound 4: middle estimate off by 2.1-fold (0.32 log units), on the low side, within the range that was stated.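

In this assay, among these compounds, morpholin-4-yl in place of diisopropylamino on the thiocarbonyl carbon gives a 1.5-fold lower number from compound 3 to compound 4 (0.18 log units; within the scatter), so on this core the change produces no step that stands clear of the usual scatter. The data do not show whether the step carries over from one core to the other at the same size: the same change on two cores in this assay, an at least 3.3-fold lower number (0.53 log units; beyond the scatter) from compound 1 to compound 2 and a 1.5-fold lower number (0.18 log units; within the scatter) from compound 3 to compound 4; the limit leaves it open whether they differ Compound 1 stands at a limit of the assay and not at a number, so the true size of the earlier step stays unknown: the limit of > 40000 nM in this assay, at which 1 of the 4 values shown sits.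

The compounds shown leave open how a piperidine or a dimethylamino group would behave on the same thiocarbonyl carbon. They also leave open how the change would run on any third core.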